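Changing the ring on sulfur in compound 3

The compounds below may be only part of what the source reports. "The series", "measured", "known", "first", "only" and "open" are said of these compounds alone.

Compounds that share one core were tested in a functional assay on MCF7 cells (Homo sapiens) for inhibition, read by MTT assay, with a stated time of 72 h (on this read-out higher numbers stand for weaker inhibition and lower numbers for stronger inhibition), where compound 1 `FC(F)(F)c1ccc(CSc2nc(N3CCNCC3)cc(C(F)(F)F)n2)cc1` gives 10700 nM and compound 2 `Cc1csc(Sc2cc(C(F)(F)F)nc(SCc3ccc(C(F)(F)F)cc3)n2)n1` gives 14500 nM. Compound 3 `Cc1nnc(Sc2cc(C(F)(F)F)nc(SCc3ccc(C(F)(F)F)cc3)n2)s1` reads > 50000 nM, which is a limit and not a number. Its steps from both other compounds lie beyond the scatter, so compound 3 stands at the weak end of this small set.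

Compound 4 `FC(F)(F)c1ccc(CSc2nc(SC3=NCCS3)cc(C(F)(F)F)n2)cc1` has not yet been measured. Its difference from compound 3 is a group of 5 heavy atoms (3 carbon, 1 nitrogen, 1 sulfur; one five-membered non-aromatic ring with 2 hetero atoms) in place of a group of 6 heavy atoms (3 carbon, 2 nitrogen, 1 sulfur; one five-membered aromatic ring with 3 hetero atoms), on a sulfur: the aromatic 5-methyl-1,3,4-thiadiazol-2-yl leaves and a five-membered non-aromatic ring enters.

The closest measured change also swaps the ring on that sulfur, and it gave an at least 3.4-fold higher number from compound 2 to compound 3 (0.53 log units; beyond the scatter). Two wider changes replace piperazin-1-yl, giving a 1.4-fold higher number from compound 1 to compound 2 (0.13 log units; within the scatter) and an at least 4.6-fold higher number from compound 1 to compound 3 (0.66 log units; beyond the scatter). For the measured compounds named here, the ring on the sulfur can therefore matter, though neither measured ring resembles the one in compound 4 closely. A modest move towards stronger inhibition in this assay is expected, of about the size seen between compound 2 and compound 3, and a reading at the limit remains possible. That means an expected at least 2.5-fold lower number from compound 3 to compound 4 (0.39 log units; beyond the scatter). For compound 4 the estimated value is 20000 nM, with an expected range from 8000 nM to 50000 nM.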

Compound 4, half-maximal inhibitory concentration: 44900 nM
Compound 4: the middle estimate sits 2.2-fold (0.35 log units) below what was measured; measured number inside the range.
By their numbers in this assay, from the lowest: compounds 1 and 2 (each within the scatter of the next); then compound 4. At a limit, above all of these: compound 3.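

Replacing the aromatic 5-methyl-1,3,4-thiadiazol-2-yl on this sulfur with a five-membered non-aromatic ring gives an at least 1.1-fold lower number from compound 3 to compound 4 (0.04 log units; that floor lies within the scatter). That step is only a floor, since one end of it is a limit and not a number: the limit of > 50000 nM in this assay, at which 1 of the 4 values shown sits.

What compound 4 adds is a real number for a weak compound at this position, one that can be set against the two stronger compounds in this assay: the non-aromatic ring in place of 4-methyl-1,3-thiazol-2-yl gives a 3.1-fold higher number from compound 2 to compound 4 (0.49 log units; beyond the scatter), and the sulfur-linked ring in place of piperazin-1-yl on the aromatic carbon gives a 4.2-fold higher number from compound 1 to compound 4 (0.62 log units; beyond the scatter). Among these four compounds, then, the piperazin-1-yl and the 4-methyl-1,3-thiazol-2-yl groups are the two that give clearly lower numbers than compound 4, and the non-aromatic ring does not join them.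

The compounds shown leave open whether compound 4 truly differs from compound 3, as the limit hides how far the true value of compound 3 lies from that of compound 4. They also leave open what a morpholine ring, a simple amine or a carboxylic acid would give on this aromatic carbon.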